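Swapping a fused aromatic group for a saturated ring

This account rests on a few compounds, and the source may have more. Where it says the series, first, only, none or still open, it means among the compounds named here.

Three compounds share one core and differ in the groups attached to it. Compound 1 `Cc1cc(Nc2cc(-c3ccccc3)[nH]n2)n2nc(SCc3csc4ccccc34)nc2n1` was tested in a functional assay on MCF7 cells (Homo sapiens) for inhibition, read by MTT assay, with a stated time of 72 h (a higher number here means a weaker inhibitor, a lower number a stronger inhibitor), and gave 3470 nM. Compound 2 `Cc1cc(Nc2ccn(Cc3nc(C)c4ccccc4n3)n2)n2nc(SCc3ccc(Br)cc3)nc2n1` gave 1430 nM in this assay, and compound 3 `Cc1cc(Nc2cc(-c3ccc(F)cc3)[nH]n2)n2nc(SCc3ccc(Br)cc3)nc2n1` gave 4570 nM. Among these three numbers compound 1 stands second highest: its number and that of compound 3 sit within the usual scatter, so no order between them can be claimed, while compound 2 shows a lower number by a margin beyond the scatter.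

Compound 4 `Cc1cc(Nc2cc(-c3ccccc3)[nH]n2)n2nc(SCC3CCCCC3)nc2n1` has not yet been measured. Compared with compound 1 the change is cyclohexyl in place of 1-benzothiophen-3-yl on a saturated chain carbon bound to a sulfur. Going by the values given here, no measured pair in this set shows the same change, so the expectation rests on the structural alteration alone. The step from compound 1 to compound 4 is expected to be small and, if anything, toward a higher number, as estimated by a 1.6-fold higher number from compound 1 to compound 4 (0.20 log units; within the scatter). For compound 4 in this assay the estimated value is 5500 nM, with a plausible range from 2000 nM to 16000 nM.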

Compound 4, half-maximal inhibitory concentration: > 50000 nM
Compound 4: no number, only a limit; the forecaster's own chance of this, stated with the estimate: 10%; at least 9.0-fold (0.95 log units) between middle value and limit.
By their numbers in this assay, from the lowest: compound 2; then compounds 1 and 3 (each within the scatter of the next). At a limit, above all of these: compound 4.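

Going by these compounds alone, with this assay, putting cyclohexyl in place of 1-benzothiophen-3-yl on a saturated chain carbon bound to a sulfur gives an at least 14-fold higher number from compound 1 to compound 4 (1.15 log units; beyond the scatter), the first step here that isolates a single place, and it shows that this position is far from indifferent to the group it carries. The reading for compound 4 is a limit of the assay and not a number: the limit of > 50000 nM in this assay, at which 1 of the 4 values shown sits. The change replaces a fused pair of aromatic rings containing a sulfur with one non-aromatic carbon ring of fewer heavy atoms, so this single step does not separate those differences.

Which of them matters remains open, and naphthalen-1-yl at this place would keep two aromatic rings without the ring sulfur. Piperidin-4-yl, which brings in an amine, would test another saturated ring.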